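A few compounds are considered here, and "the series" means these few. Any claim that something is new, unique, unknown or untested is made for them only; others in the source may bear on it.

Three compounds share one core. Compound 1 `CC(C)CCn1c(N2CCN(C)CC2)nc2ccccc21` gives 1400 nM in a functional assay on ileum for inhibition of histamine H1 receptor (Cavia porcellus); a lower number here means a stronger inhibitor, a higher number a weaker inhibitor. Compound 2 `CCCCCN1CCN(c2nc3ccccc3n2CCOCC)CC1` gives 30 nM, and compound 3 `CCCCCCn1c(N2CCN(C)CC2)nc2ccccc21` gives 26 nM, so compound 3 and compound 2 lie within the usual scatter of each other, while compound 1 sits far higher. The only step shown, a 54-fold lower number from compound 1 to compound 3 (1.73 log units; beyond the scatter), replaces a branched chain by a straight one. Compound 4 `CCCC(C)Cn1c(N2CCN(C)CC2)nc2ccccc21` goes the other way: 1-methylbutyl in place of pentyl on a saturated chain carbon bound to an aromatic nitrogen. The branch in compound 4 sits on the carbon bound to the aromatic nitrogen, whereas in compound 1 it sat two bonds along the chain from it, so the step of a 54-fold lower number from compound 1 to compound 3 (1.73 log units; beyond the scatter) bears on it only loosely. Compound 4 is nonetheless expected to give a higher number than compound 3, with an expected step of a 3.8-fold higher number from compound 3 to compound 4 (0.59 log units; beyond the scatter). Compound 4 is estimated at 100 nM, between 30 nM and 400 nM.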

Compound 4, half-maximal inhibitory concentration: 500 nM
Compound 4: middle estimate off by 5.0-fold (0.70 log units), on the low side; the whole stated range lies below it.
By their numbers in this assay, from the lowest: compounds 3 and 2 (each within the scatter of the next); then compound 4; then compound 1.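

Swapping pentyl for 1-methylbutyl on a saturated chain carbon bound to an aromatic nitrogen gives a 19-fold higher number from compound 3 to compound 4 (1.28 log units; beyond the scatter) in this assay and leaves the atoms unchanged, so rearranging the chain alone can produce a large step at this position. The change from isobutyl to 1-methylbutyl at the same place gives only a 2.8-fold lower number from compound 1 to compound 4 (0.45 log units; beyond the scatter) and leaves both branched compounds well above compound 3. Nothing available explains the size of these steps. From the compounds shown here alone, it remains open whether a longer straight chain, such as heptyl, would keep the low number of compound 3. An amine at the chain end is equally untested by the compounds shown here.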